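This account rests on a few compounds, and the source may have more. Where it says the series, first, only, none or still open, it means among the compounds named here.

Measured compounds: compound 1 `CC(=O)/C(=N\c1cccc(Cl)c1)NNc1ccccc1[N+](=O)[O-]` with 51 nM; compound 2 `CC(=O)/C(=N\Nc1ccccc1[N+](=O)[O-])N(C)c1cccc(Cl)c1` with 8600 nM; compound 3 `CC(=O)/C(=N\Nc1ccccc1C#N)Nc1cccc(Cl)c1` with 415 nM; 415 nM (2 entries).

In an assay on isolated protein for binding affinity to corticotropin-releasing factor receptor 1 (Homo sapiens) (on this read-out lower numbers stand for stronger inhibition and higher numbers for weaker inhibition), compound 2 holds the higher of the two single numbers; its nearest neighbour, compound 1, lies far lower, a gap beyond the usual scatter, while compound 3 contributes two matching entries. Compound 4 `CC(=O)/C(=N\Nc1ccccc1C)N(C)c1cccc(Cl)c1` has not yet been measured. It differs from compound 2 in one place: methyl in place of nitro on an aromatic carbon. Going by the values given here, no pair of measured compounds covers this exchange, so only a rough guide exists: compound 1 and compound 3 differ at that same position, and the nitro partner carries the lower number. The move in this assay is therefore expected to raise the number, by a 2.3-fold higher number from compound 2 to compound 4 (0.37 log units; beyond the scatter). Compound 4 is estimated at 20000 nM, within 5000 nM to 80000 nM.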

Compound 4, inhibition constant: > 10000 nM
Compound 4 ended at the assay's limit (the forecaster's own chance of this, stated with the estimate: 30%); the middle value lies beyond the limit too.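

In this assay compound 4 gives > 10000 nM, which is a limit of the assay and not a number. The exchange of nitro for methyl on this aromatic carbon, ortho to a large group, can therefore be read only as a floor, an at least 1.1-fold higher number from compound 2 to compound 4 (0.06 log units; that floor lies within the scatter). This direct pair shows that methyl gives no measurable number here, but it does not establish a real loss against nitro.

From the compounds shown here alone, it remains open whether an amine or a carboxylic acid at this position would give a measurable number. Also open, going by these compounds, is how methyl would behave on the core of compound 3.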